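Bromo on the phenyl ring of compound 1

This account rests on a few compounds, and the source may have more. Where it says the series, first, only, none or still open, it means among the compounds named here.

Compound 1 `COc1cc(/C=N/Nc2nc(-c3ccccc3)cs2)c(Br)c(Br)c1OC` is one of three hydrazone thiazoles measured in a functional assay on HepG2 cells (Homo sapiens) for inhibition, read by MTT assay, with a stated time of 48 h; a higher number here means a weaker inhibitor, a lower number a stronger inhibitor. In this assay compound 1 gives 33600 nM, the second highest of the three numbers. Compound 3 `COc1cc(/C=N/Nc2nc(-c3ccccc3)cs2)cc(Br)c1OC` gives 68300 nM, and compound 2 `Fc1ccc(/C=N/Nc2nc(-c3ccc(C(F)(F)F)cc3)cs2)cc1F` gives 14500 nM. For the measured compounds named here, the only single-point step among them, a 2.0-fold higher number from compound 1 to compound 3 (0.31 log units; beyond the scatter), shows that taking a bromo off the benzylidene ring of compound 1 weakens inhibition modestly.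

Compound 4 `COc1cc(/C=N/Nc2nc(-c3cccc(Br)c3)cs2)c(Br)c(Br)c1OC` differs from compound 1 in a different place: bromo in place of hydrogen on an aromatic carbon. Going by the values given here, no measured pair changes this phenyl ring alone; compound 2 carries a trifluoromethyl there but also has a different benzylidene ring, so it offers only a loose hint toward a lower number. Among the compounds with values here, the one measured step shows that a bromo can matter, but on the other ring. The author therefore expects a small change, if any, and estimates for compound 4 25000 nM, within 8000 nM to 80000 nM, a step of a 1.3-fold lower number from compound 1 to compound 4 (0.13 log units; within the scatter) that may well sit inside the scatter.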

Compound 4, half-maximal inhibitory concentration: > 100000 nM
Compound 4 was reported as a limit (the forecaster's own chance of this, stated with the estimate: 10%); middle value at least 4.0-fold (0.60 log units) away from the limit.
By their numbers in this assay, from the lowest: compound 2; then compound 1; then compound 3. At a limit, above all of these: compound 4.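

Bromo in place of hydrogen on this phenyl ring gives an at least 2.9-fold higher number from compound 1 to compound 4 (0.47 log units; beyond the scatter) in this assay, so inhibition weakens and this ring proves sensitive to a single added atom. The direction differs from that of the earlier step. There, a 2.0-fold higher number from compound 1 to compound 3 (0.31 log units; beyond the scatter) came with the loss of a bromo from the other ring, and a higher number follows both adding a bromo on one ring and removing one from the other. Compound 4 stands only at a limit, so this step has a lower bound and no measured size: the limit of > 100000 nM in this assay, at which 1 of the 4 values shown sits.

From the compounds shown here alone, whether a fluoro, a methoxy or an amine on this aromatic carbon would also raise the number remains open. Also open, going by these compounds, is whether the same bromo would give a similar step with a different group pattern on the other ring.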